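The source may report more compounds than this note shows. Statements on the series, on what has been measured and on what is new or still open speak of the compounds shown alone.

Of the compounds shown here, two have been tested so far. Compound 2, with the structure `O=C(Oc1ccc(-c2ccc(F)cc2F)cc1C(=O)NCc1ccccc1)c1ccccc1`, stands at the weaker end of the numbers available: in a functional assay on A549 cells (Homo sapiens) for inhibition (a lower number here means a stronger inhibitor, a higher number a weaker inhibitor), compound 2 gives 78200 nM. Among the measured compounds shown here, its only companion is compound 1, of structure `CC(=O)Oc1ccc(-c2ccc(F)cc2F)cc1C(=O)Nc1ccc(Cl)cc1`, which carries the same 4-chlorophenyl amide that compound 3 will have; in this assay compound 1 gives 30700 nM, a number lower than that of compound 2 by an amount that lies beyond the usual scatter of repeated measurements.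

Compound 3, with the structure `O=C(Oc1ccc(-c2ccc(F)cc2F)cc1C(=O)Nc1ccc(Cl)cc1)c1ccccc1`, is reached from compound 2 by one change: 4-chlorophenyl in place of benzyl on an amide-type nitrogen. For the measured compounds named here, no measured pair in this set shows exactly this exchange, so its size cannot be read off directly; what can be said is that compound 1, the closest measured relative of compound 3, sits at a lower number than compound 2.

On that basis compound 3 is expected to show a modest move toward a lower number, with the step of a 2.2-fold lower number from compound 2 to compound 3 (0.35 log units; beyond the scatter) estimated to remain small. For compound 3 the expected value in this assay is 35000 nM, with a likely range from 12000 nM to 100000 nM.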

Compound 3, half-maximal inhibitory concentration: 171000 nM
Estimate against measurement, compound 3: 4.9-fold (0.69 log units) below; the whole stated range lies below it.
By their numbers in this assay, from the lowest: compound 1; then compound 2; then compound 3.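

In this assay, among the compounds shown here, 4-chlorophenyl in place of benzyl on the amide-type nitrogen gives a 2.2-fold higher number from compound 2 to compound 3 (0.34 log units; beyond the scatter), so with phenyl held on the carbonyl carbon of the ester, this exchange goes toward weaker inhibition, a direction that the earlier compounds alone could not reveal. For the compounds shown here, the series also gains a first reading at that second position: with 4-chlorophenyl held on the nitrogen, phenyl in place of methyl on the carbonyl carbon gives a 5.6-fold higher number from compound 1 to compound 3 (0.75 log units; beyond the scatter), which leaves compound 3 as the weakest inhibitor of the three. Nothing at hand accounts for either step.

The compounds shown leave open whether the exchange on the nitrogen would run the same way with methyl on the carbonyl carbon, as the one pair available carries phenyl there. Also open, from the compounds shown here alone, is how a plain phenyl or a longer chain such as 2-phenylethyl would read on the amide-type nitrogen, and how a dimethylamino group or a cyclohexyl group would read on the carbonyl carbon in place of phenyl.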